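Iodine Added to an Inactive Core

The compounds below may be only part of what the source reports. "The series", "measured", "known", "first", "only" and "open" are said of these compounds alone.

Of the compounds shown here, three have so far been measured in a functional assay on HeLa cells (Homo sapiens) for inhibition, read by MTT assay, with a stated time of 72 h; on this read-out higher numbers stand for weaker inhibition and lower numbers for stronger inhibition. Compound 1, `Cn1cc(CO)c(N)nc1=O`, gives > 100000 nM, which is a limit of the assay rather than a number. Compound 2, `Cc1cc(=O)[nH]c(=O)n1COC(CO)CO`, gives > 100000 nM, again a limit. Compound 3, `O=c1ccn(COC(CO)CO)c(=O)[nH]1`, gives > 100000 nM, also a limit.

Compound 2 therefore does not stand at any readable point: its value is only a limit, and the two other values shown are limits as well. Going by the values given here, the one step between measured compounds, a step that the two limits leave unreadable from compound 2 to compound 3, cannot be read because of the limit of > 100000 nM in this assay, at which 3 of the 3 values shown sit.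

Compound 4, `Cc1c(I)c(=O)[nH]c(=O)n1COC(CO)CO`, has not yet been measured. It differs from compound 2 in one place: iodo in place of hydrogen on an aromatic carbon. Among the compounds with values here, no measured step bears on this change, and the only step in the set is itself unreadable. There is no evidence on which a direction or size for the step from compound 2 to compound 4 could rest, and the most likely outcome is that the assay again reports only a limit.

Compound 4 is therefore estimated at 100000 nM, with a range from 20000 nM to 400000 nM, meaning an expected step of a number no higher from compound 2 to compound 4 (the limit leaves the size open).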

Compound 4, half-maximal inhibitory concentration: 73000 nM
Estimate against measurement, compound 4: 1.4-fold (0.14 log units) above; measured number inside the range.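

Going by these compounds alone, at this position, on the aromatic carbon ortho to a methyl group, iodo in place of hydrogen gives the first value in this assay that is a number and not a limit. The change itself reads as an at least 1.3-fold lower number from compound 2 to compound 4 (0.13 log units; that floor lies within the scatter), so the true step may be larger than this floor, but what can be read of it does not go beyond ordinary repeat variation. That floor is all that the data give for this change, and the step from compound 2 to compound 3 cannot be read at all, because the values at both of its ends are limits: the limit of > 100000 nM in this assay, at which 3 of the 4 values shown sit.

As far as these compounds go, what a bromine atom, an amine or a carboxylic acid would do on this same aromatic carbon remains open, so it cannot yet be said whether the number seen for compound 4 is particular to iodo. Also open, from the compounds shown here alone, is whether iodo would give a readable number on the core of compound 3, which carries hydrogen in place of the methyl group, and whether a longer chain at that methyl position would change the picture.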